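A Side Chain Swap at the Assay Limit

A few compounds are considered here, and "the series" means these few. Any claim that something is new, unique, unknown or untested is made for them only; others in the source may bear on it.

Compound 1 `CCOC(=O)c1c(-c2cccc(C(C)=O)c2)[nH]c2cc(OC)ccc2c1=O` gives > 21500 nM (a limit)
Compound 2 `CCOC(=O)c1c(-c2cccc([N+](=O)[O-])c2)[nH]c2cc(OC)ccc2c1=O` gives > 21500 nM (a limit)
Compound 3 `COc1cc2[nH]c(-c3cccc(Oc4ccccc4)c3)c(C(=O)NCCN3CCCC3)c(=O)c2cc1F` gives > 21500 nM (a limit)

All three entries come from an ADME assay on HepG2 cells (Homo sapiens) for cytotoxicity, read by luminescence, with a stated time of 72 h (on this read-out higher numbers stand for an effect only at larger amounts of compound and lower numbers for an effect already at smaller amounts), and are limits, not numbers (the limit of > 21500 nM in this assay, at which 3 of the 3 values shown sit).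

Compound 3 therefore has no exact position, only a limit. Compound 4 `COCCOC(=O)c1c(-c2cccc(Oc3ccccc3)c2)[nH]c2cc(OC)c(F)cc2c1=O` differs from it in one place: 2-methoxyethoxy in place of (2-(pyrrolidin-1-yl)ethyl)amino on a carbonyl carbon, with 2-methoxyethoxy in place of (2-(pyrrolidin-1-yl)ethyl)amino on a carbonyl carbon.

Among the measured compounds shown here, the only measured step, a step that the two limits leave unreadable from compound 1 to compound 2, is a different change and offers no size to carry over. No readable shift or direction is therefore expected in this assay, and a limit is the likeliest result.

The estimated change is a step that the limit leaves unreadable from compound 3 to compound 4, which is no readable step.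

For compound 4 the estimate is 30000 nM, with an expected range from 15000 nM to 60000 nM.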

Compound 4, half-maximal effective concentration: > 21500 nM
Compound 4: only a limit was reported; the forecaster's own chance of this, stated with the estimate: 85%; the middle value does not contradict the limit.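

Compound 3 and compound 4 both give only a limit, so no step can be read between them: the limit of > 21500 nM in this assay, at which 4 of the 4 values shown sit. Still open, on these data alone, is where in this assay any of these four compounds would give an actual number.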